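The source may hold more compounds than are shown below. What is called first, only, known or untested is meant among the compounds shown, and "the series" means these compounds.

In a functional assay on FaDu cells (Homo sapiens) for cytotoxicity, read by MTT assay, with a stated time of 72 h (on this read-out higher numbers stand for lower toxicity in this test and lower numbers for higher toxicity in this test), compound 1 `COc1ccc(NC(=O)C(=O)c2cn(C(C)C)c3ccccc23)cn1` gives 85 nM and compound 2 `COc1ccc(NC(=O)C(=O)c2cn(C3CCCC3)c3ccccc23)cn1` gives 370 nM, the higher of the two numbers. Compound 3 `COc1ccc(NC(=O)C(=O)c2cn(CC(C)C)c3ccccc23)cn1` has isobutyl in place of cyclopentyl on an aromatic nitrogen. Among the compounds with values here, one measured step bears on this place, the modest 4.4-fold higher number from compound 1 to compound 2 (0.64 log units; beyond the scatter), which lies beyond the scatter and put cyclopentyl in place of isopropyl. Isobutyl, like the isopropyl of compound 1 at 85 nM, has no ring, so a partial return towards that lower number is expected. The expected size of this move is a 2.2-fold lower number from compound 2 to compound 3 (0.34 log units; beyond the scatter). The estimate for compound 3 is 170 nM, within a range of 60 nM to 480 nM.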

Compound 3, concentration lethal to 50% of the cells: 317 nM
Estimate against measurement, compound 3: 1.9-fold (0.27 log units) below; low and high end bracket the measured number.
By their numbers in this assay, from the lowest: compound 1; then compounds 3 and 2 (each within the scatter of the next).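

Moving from cyclopentyl to isobutyl on the aromatic nitrogen gives a 1.2-fold lower number from compound 2 to compound 3 (0.07 log units; within the scatter) in this assay, so losing the ring makes no clear difference here. Isobutyl in place of isopropyl gives a 3.7-fold higher number from compound 1 to compound 3 (0.57 log units; beyond the scatter), so having no ring is not enough to keep the lower number of compound 1. Nothing available explains why these close groups differ. The compounds shown leave open how an ethyl group, a straight propyl chain or a chain ending in an amine would read at this nitrogen.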